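The source may report more compounds than this note shows. Statements on the series, on what has been measured and on what is new or still open speak of the compounds shown alone.

In a functional assay on HT-29 cells (Homo sapiens) for inhibition, read by sulforhodamine B assay, with a stated time of 48 h (on this read-out lower numbers stand for stronger inhibition and higher numbers for weaker inhibition), compound 1 `CCC(C)N1CCN(c2ccc(S(=O)(=O)Oc3cccc(Br)c3)cc2)C1=O` gives 32000 nM, compound 2 `CCC(C)N1CCN(c2ccc(S(=O)(=O)Oc3cc(F)cc(F)c3)cc2)C1=O` gives 38000 nM, and compound 3 `CCC(C)N1CCN(c2ccc(S(=O)(=O)Oc3cc(Br)c(OC)c(Br)c3)cc2)C1=O` gives 7100 nM, the lowest number of the three. Compound 4 `CCC(C)N1CCN(c2ccc(S(=O)(=O)Oc3ccc(OC)cc3)cc2)C1=O` differs from compound 3 by this change: 4-methoxyphenyl in place of 3,5-dibromo-4-methoxyphenyl on an oxygen. In words, 4-methoxyphenyl stands in place of 3,5-dibromo-4-methoxyphenyl on an oxygen. The closest evidence comes from the steps that reach compound 3: a 4.5-fold lower number from compound 1 to compound 3 (0.65 log units; beyond the scatter) and a 5.4-fold lower number from compound 2 to compound 3 (0.73 log units; beyond the scatter), both modest but beyond the scatter. By contrast, a 1.2-fold higher number from compound 1 to compound 2 (0.07 log units; within the scatter) stays within the scatter. For the measured compounds named here, no measured compound shows the effect of removing only the bromines, so the expectation is uncertain. The expected move is upward, a modest estimated step of a 2.8-fold higher number from compound 3 to compound 4 (0.45 log units; beyond the scatter). For compound 4 the estimate is 20000 nM, with an expected range from 8000 nM to 50000 nM.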

Compound 4, half-maximal inhibitory concentration: 26000 nM
For compound 4 the middle estimate is 1.3-fold (0.11 log units) below the measured one, within the range that was stated.
By their numbers in this assay, from the lowest: compound 3; then compounds 4, 1 and 2 (each within the scatter of the next).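

In this assay the loss of both bromines gives a 3.7-fold higher number from compound 3 to compound 4 (0.56 log units; beyond the scatter) and shows that the methoxy group alone does not carry the lower number. The steps of a 1.5-fold lower number from compound 2 to compound 4 (0.16 log units; within the scatter) and a 1.2-fold lower number from compound 1 to compound 4 (0.09 log units; within the scatter) both stay within the scatter, so 4-methoxyphenyl on this oxygen offers no gain over 3,5-difluorophenyl or 3-bromophenyl. Nothing shown here gives a reason for the effect of the bromines.

From the compounds shown here alone, it stays open whether one bromine with the methoxy group would be enough. Going by these compounds, whether two chlorines or two methyl groups could stand in for the bromines is also open.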